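This account rests on a few compounds, and the source may have more. Where it says the series, first, only, none or still open, it means among the compounds named here.

Measured so far:
Compound 1, `N=C(N)NCCC[C@H](N)C(=O)NCC(=O)N[C@@H](CC(=O)O)C(=O)N[C@@H](CSCc1cn(CCO[C@H]2O[C@H](CO)[C@@H](O)[C@H](O)[C@@H]2O)nn1)C(=O)O`, in a functional assay on a cell-free system (Platelet, plasma, Homo sapiens) for inhibition, with a stated time of 10 min, at 37 degrees C (a lower number here means a stronger inhibitor, a higher number a weaker inhibitor), gives 47600 nM.
Compound 2, `N=C(N)NCCC[C@H](N)C(=O)NCC(=O)N[C@@H](CC(=O)O)C(=O)N[C@@H](CSCc1cn(CCO[C@H]2O[C@H](CF)[C@@H](O)[C@H](O)[C@@H]2O)nn1)C(=O)O`, in this assay gives 23500 nM.

Both compounds share one peptide core joined through a triazole to a sugar, and differ only in that sugar. In this assay, among the compounds with values here, compound 2 stands at the lowest of the two numbers, the only step to it being a 2.0-fold lower number from compound 1 to compound 2 (0.31 log units; beyond the scatter). Compound 3, `N=C(N)NCCC[C@H](N)C(=O)NCC(=O)N[C@@H](CC(=O)O)C(=O)N[C@@H](CSCc1cn(CCO[C@@H]2O[C@H](CO)[C@@H](O)[C@H](O)[C@H]2O)nn1)C(=O)O`, has not yet been measured. Its difference from compound 2 is a group of 11 heavy atoms (6 carbon, 5 oxygen; one six-membered non-aromatic ring with 1 hetero atom) in place of a group of 11 heavy atoms (6 carbon, 4 oxygen, 1 fluorine; one six-membered non-aromatic ring with 1 hetero atom), on an oxygen on a saturated carbon. Within the data shown here, the single measured step bears on this only in part: it shows that putting fluorine in place of hydroxy on the sugar arm gave the modest change a 2.0-fold lower number from compound 1 to compound 2 (0.31 log units; beyond the scatter), so returning to hydroxy might undo it, but the sugar in compound 3 also carries a different arrangement of its stereocentres than the sugar in compound 1, and nothing measured speaks to that. For compound 3 a return towards the value of compound 1 is expected, a step of a 1.9-fold higher number from compound 2 to compound 3 (0.28 log units; within the scatter), with wide uncertainty. Compound 3 is therefore estimated at 45000 nM, in the range 15000 nM to 130000 nM.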

Compound 3, half-maximal inhibitory concentration: 44000 nM
Compound 3: middle estimate off by 1.0-fold (0.01 log units), on the high side, and the stated range covers the measured number.
By their numbers in this assay, from the lowest: compounds 2, 3 and 1 (each within the scatter of the next, the first and the last beyond it).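

Redrawing two saturated ring carbons of the sugar, with the same atoms and bonds, gives a 1.1-fold lower number from compound 1 to compound 3 (0.03 log units; within the scatter), so in this assay the new sugar arrangement cannot be told apart from the sugar of compound 1. The other new step, a 1.9-fold higher number from compound 2 to compound 3 (0.27 log units; within the scatter), also stays within the scatter, so the fluorine-bearing sugar and the sugar of compound 3 cannot be separated either, even though the fluoro step from the first sugar lay just beyond it. The comparison of the two sugar arrangements carries one caution: the fact that one of compounds 1 and 3 is drawn with a defined configuration and the other without, at the place where they differ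

From the compounds shown here alone, it remains open whether fluoro in place of hydroxy on the sugar of compound 3 would give a step like the one seen on the sugar of compound 1. Also open, going by these compounds, is how an amine or a methoxy group would fare in that same place on either sugar.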